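Swapping phenyl for pyridin-4-yl on a hydroxyphenyl pyridine

The source may report more compounds than this note shows. Statements on the series, on what has been measured and on what is new or still open speak of the compounds shown alone.

Compound 2 `Oc1cccc(-c2cc(-c3ccccc3)nc(-c3ccc(Cl)cc3)c2)c1` was tested in a functional assay on HCT-15 cells (Homo sapiens) for cytotoxicity, read by CCK-8 assay and cell counting, with a stated time of 2 days (a higher number here means a weaker inhibitor, a lower number a stronger inhibitor), where compound 2 gives 8110 nM. For the measured compounds named here, only one other compound has been measured: compound 1 `Oc1cccc(-c2cc(-c3ccc(Cl)cc3)nc(-c3ccccn3)c2)c1`, which in this assay gives 13500 nM. Going by the values given here, the single step recorded, a 1.7-fold lower number from compound 1 to compound 2 (0.22 log units; within the scatter), is within the scatter, so compound 2 and compound 1 cannot be told apart on these numbers.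

Compound 3 `Oc1cccc(-c2cc(-c3ccncc3)nc(-c3ccc(Cl)cc3)c2)c1` differs from compound 2 by pyridin-4-yl in place of phenyl on an aromatic carbon. Among the compounds with values here, the one step that bears on this, from compound 1 to compound 2, also exchanged a pyridyl ring for a phenyl ring and produced no shift beyond the scatter. Within the data shown here, nothing measured so far suggests that putting a ring nitrogen back in should move this assay far in either direction. Compound 3 is therefore expected to give 9000 nM, with a range from 3500 nM to 25000 nM. This corresponds to an expected step of a 1.1-fold higher number from compound 2 to compound 3 (0.05 log units; within the scatter), which is no change beyond the scatter.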

Compound 3, half-maximal inhibitory concentration: 2630 nM
For compound 3 the middle estimate is 3.4-fold (0.53 log units) above the measured one; the measured number lies below the stated range.
By their numbers in this assay, from the lowest: compound 3; then compounds 2 and 1 (each within the scatter of the next).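

In this assay, for the compounds shown here, the group on this aromatic carbon next to the ring nitrogen can change the number: pyridin-4-yl in place of phenyl gives the first step beyond the scatter (a 3.1-fold lower number from compound 2 to compound 3 (0.49 log units; beyond the scatter)). Pyridin-4-yl also gives a lower number than pyridin-2-yl (a 5.1-fold lower number from compound 1 to compound 3 (0.71 log units; beyond the scatter)), whereas pyridin-2-yl and phenyl cannot be told apart (a 1.7-fold lower number from compound 1 to compound 2 (0.22 log units; within the scatter)), so among these compounds the presence of a ring nitrogen alone does not go with a stronger result; where it stands in the ring does. No measurement here gives a reason for this.

The compounds shown leave open whether pyridin-3-yl would behave like pyridin-4-yl or like pyridin-2-yl. They also leave open how an amine or a carboxylic acid on the pyridin-4-yl ring would change the number.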